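The compounds below may be only part of what the source reports. "The series", "measured", "known", "first", "only" and "open" are said of these compounds alone.

Measured so far in a functional assay on Jurkat cells (Homo sapiens) for inhibition; on this read-out lower numbers stand for stronger inhibition and higher numbers for weaker inhibition:
compound 1 `CC(C)[C@H](NC(=O)COc1cccc2ccccc12)C(=O)N[C@@H](CC(=O)O)C(=O)CSc1nc(-c2ccccc2)c(-c2ccccc2)[nH]1` gives > 200000 nM, a limit of the assay.
compound 2 `CC(C)[C@H](NC(=O)COc1cccc2ccccc12)C(=O)N[C@@H](CC(=O)O)C(=O)CSc1nc(-c2ccccc2)c(-c2ccccc2)o1` gives > 200000 nM, a limit of the assay.
compound 3 `CC(C)[C@H](NC(=O)COc1cccc2ccccc12)C(=O)N[C@@H](CC(=O)O)C(=O)CSc1nc2ccccc2o1` gives > 200000 nM, a limit of the assay.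

Compound 3 thus stands at the limit of > 200000 nM in this assay, at which 3 of the 3 values shown sit, and no measured value separates it from compound 1 or compound 2. Among the measured compounds shown here, no step between measured compounds is available, since every value is a limit.

Compound 4 `CC(C)[C@H](NC(=O)COc1cccc2ccccc12)C(=O)N[C@@H](CC(=O)O)C(=O)COc1cccc2cccnc12` differs from compound 3 by (quinolin-8-yl)oxy in place of (1,3-benzoxazol-2-yl)sulfanyl on a saturated chain carbon bound to a carbonyl carbon. The part that enters carries no sulfur and the one that leaves is replaced in its entirety, so the change is not a small one.

For the measured compounds named here, with no measured step to lean on, the expectation for compound 4 is 20000 nM, within 2000 nM to 200000 nM. The step from compound 3 to compound 4 is therefore expected as an at least 10-fold lower number from compound 3 to compound 4 (1.00 log units; beyond the scatter), toward stronger inhibition, though a value at the limit is also expected to remain possible for compound 4.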

Compound 4, half-maximal inhibitory concentration: > 200000 nM
Compound 4: no number, only a limit; the forecaster's own chance of this, stated with the estimate: 40%; at least 10-fold (1.00 log units) between middle value and limit.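

In this assay compound 4 gives > 200000 nM, a limit and not a number, and the step from compound 3 to compound 4 cannot be read. Still open is whether any group on this saturated chain carbon bound to a carbonyl carbon gives a measurable inhibition, as all values share one limit: the limit of > 200000 nM in this assay, at which 4 of the 4 values shown sit.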